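The source may hold more compounds than are shown below. What is called first, only, known or untested is meant among the compounds shown, and "the series" means these compounds.

Measured compounds:
- compound 1, `CN1CCN(CCCCOc2cc(C(=O)N3CCCCc4sccc43)ccc2NC(=O)c2ccccc2-c2ccccc2)CC1`: < 0.01 mg/kg
- compound 2, `O=C(Nc1ccc(C(=O)N2CCCCc3sccc32)cc1OCCCC(=O)N1CCC(N2CCCCC2)CC1)c1ccccc1-c1ccccc1`: 0.03 mg/kg

Of the compounds shown here, two share one core and have been tested in a functional assay on the whole organism for antagonist activity, with Rattus norvegicus as the target; on this read-out lower numbers stand for an effect already at smaller amounts and higher numbers for an effect only at larger amounts of compound. Compound 1 reaches only a limit of the assay, < 0.01 mg/kg, not a number. Among the compounds with values here, compound 2 gives 0.03 mg/kg in this assay, and this is the only actual number among the values shown; the other value is the limit of < 0.01 mg/kg in this assay, at which 1 of the 2 values shown sits.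

Compound 3, `CN1CCCN(C(=O)CCCOc2cc(C(=O)N3CCCCc4sccc43)ccc2NC(=O)c2ccccc2-c2ccccc2)CC1`, has not been tested. It differs from compound 2 in one place: 4-methyl-1,4-diazepan-1-yl in place of 4-(piperidin-1-yl)piperidin-1-yl on a carbonyl carbon. Within the data shown here, since no step between two measured compounds is available, there is nothing to lean on beyond the number for compound 2 itself. The change in this assay is expected to stay small, with no clear direction beyond the usual scatter. Compound 3 is expected to give about 0.03 mg/kg, within 0.01 mg/kg to 0.1 mg/kg, which means an expected step of no change at the digits printed from compound 2 to compound 3 (within the scatter).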

Compound 3, dose for 50% inhibition: 0.008 mg/kg
Beside the measured number, compound 3's estimate is 3.8-fold (0.57 log units) above it; measured number outside the range, below it.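

In this assay, the group on the carbonyl carbon turns out to matter: 4-methyl-1,4-diazepan-1-yl in place of 4-(piperidin-1-yl)piperidin-1-yl gives a 3.8-fold lower number from compound 2 to compound 3 (0.57 log units; beyond the scatter). Within the data shown here, with only one number available before, nothing could show how this position responds, and now one change here is seen to move the read-out beyond the usual scatter, with the group of fewer heavy atoms carrying the lower number. Compound 1 carries a limit rather than a number, so its step to compound 3 cannot be read: the limit of < 0.01 mg/kg in this assay, at which 1 of the 3 values shown sits.

A single step cannot separate the effect of ring size from that of losing the second ring. As far as these compounds go, how a simpler group such as morpholin-4-yl on the same carbonyl carbon would compare remains open.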